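Carbamate to Urea on a Biaryl Dimethylamine Scaffold

The source may report more compounds than this note shows. Statements on the series, on what has been measured and on what is new or still open speak of the compounds shown alone.

The measured compounds are: compound 1, `CN(C)c1ccc(-c2cccc([N+](=O)[O-])c2)cc1`, with > 200000 nM; compound 2, `CN(C)C(=O)Nc1cccc(-c2ccc(N(C)C)cc2)c1`, with < 5000 nM; and compound 3, `CC(C)OC(=O)Nc1cccc(-c2ccc(N(C)C)cc2)c1`, with 82000 nM.

In an assay on COS-7 cells for inhibition of patatin-like phospholipase domain-containing protein 2 (Mus musculus) (a lower number here means a stronger inhibitor, a higher number a weaker inhibitor), compound 3 gives 82000 nM. For compound 1 the value is only a limit of this assay, > 200000 nM. For compound 2 the value is likewise a limit of this assay, < 5000 nM. Within the data shown here, compound 3 thus carries the only number read as a number in this set, the other two sitting at a limit.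

Compound 4, `CN(C)c1ccc(-c2cccc(NC(=O)N3CCOCC3)c2)cc1`, has not yet been measured. It differs from compound 3 by morpholin-4-yl in place of isopropoxy on a carbonyl carbon. The measured step that bears on this change is an at least 16-fold higher number from compound 2 to compound 3 (1.21 log units; beyond the scatter), in which a dimethylamino on the carbonyl carbon was exchanged for isopropoxy and the number rose by a large amount. Compound 4 moves in the opposite direction, back from an alkoxy to a nitrogen substituent on that carbonyl carbon, so a large fall in the number is expected, of about a 21-fold lower number from compound 3 to compound 4 (1.31 log units; beyond the scatter). Compound 4 is therefore estimated at 4000 nM, in the range 800 nM to 20000 nM.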

Compound 4, half-maximal inhibitory concentration: > 200000 nM
Compound 4 ended at the assay's limit (the forecaster's own chance of this, stated with the estimate: 40%); middle value at least 50-fold (1.69 log units) from the limit.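

In this assay, a nitrogen on the carbonyl carbon proves insufficient in itself to give the fall in number seen with the dimethylamino group, since the morpholin-4-yl group goes the other way, with an at least 2.4-fold higher number from compound 3 to compound 4 (0.38 log units; beyond the scatter). The contrast between the two nitrogen groups is large, with an at least 40-fold higher number from compound 2 to compound 4 (1.60 log units; beyond the scatter), so at this position the result depends on which nitrogen group is attached and not merely on replacing isopropoxy with a nitrogen substituent. Neither step has a fixed upper size, since compound 4 reaches an assay limit rather than giving a number: the limit of > 200000 nM in this assay, at which 2 of the 4 values shown sit.

What the compounds shown leave open is whether the ring as such or its oxygen goes with the higher number, a question that a piperidin-1-yl or a diethylamino group on the same carbonyl carbon would help to separate. From the compounds shown here alone, the true value of compound 2 also stays open, as it too is only a limit, and with it the real size of its gap to compound 3 and compound 4.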